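Hydrazone aryl swaps on the shared core: working notes

This account rests on a few compounds, and the source may have more. Where it says the series, first, only, none or still open, it means among the compounds named here.

Measured in a functional assay on SF-295 cells (Homo sapiens) for inhibition, read by sulforhodamine B assay, with a stated time of 48 h (on this read-out higher numbers stand for weaker inhibition of growth and lower numbers for stronger inhibition of growth), so far:
compound 1 `NS(=O)(=O)c1ccc(Nc2nc(N/N=C/c3ccc(C(F)(F)F)cc3)nc(Nc3ccccc3)n2)cc1`: 1920 nM
compound 2 `Cc1nn(-c2ccccc2)cc1/C=N/Nc1nc(Nc2ccccc2)nc(Nc2ccc(S(N)(=O)=O)cc2)n1`: 223000 nM

Going by the values given here, compound 2 stands at the highest of the two numbers; its only neighbour is compound 1, and the single measured step, a 120-fold higher number from compound 1 to compound 2 (2.07 log units; beyond the scatter), is the whole of the evidence on the hydrazone aryl position. That step replaced a six-membered carbon ring by a five-membered aromatic ring and moved the number far upward.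

Compound 3 `NS(=O)(=O)c1ccc(Nc2nc(N/N=C/c3ccccn3)nc(Nc3ccccc3)n2)cc1` differs from compound 2 by pyridin-2-yl in place of 3-methyl-1-phenyl-1H-pyrazol-4-yl on a carbon with a double bond to nitrogen. This returns the position to a single six-membered aromatic ring, now with one hetero atom, so the change runs in the opposite sense to the measured step, though pyridin-2-yl is not the same group as in compound 1. Among the compounds with values here, with only that step to go on, the expectation for compound 3 is a large move toward lower numbers, estimated as a 37-fold lower number from compound 2 to compound 3 (1.57 log units; beyond the scatter), without assuming a full return to the level of compound 1. Compound 3 is therefore estimated at 6000 nM in this assay, with a range from 1200 nM to 50000 nM.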

Compound 3, concentration for 50% growth inhibition: 1400 nM
For compound 3 the middle estimate is 4.3-fold (0.63 log units) above the measured one; the measured number falls inside the stated range.
By their numbers in this assay, from the lowest: compounds 3 and 1 (each within the scatter of the next); then compound 2.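

In this assay, going by these compounds alone, the change to pyridin-2-yl gives a 160-fold lower number from compound 2 to compound 3 (2.20 log units; beyond the scatter) and so shows that the earlier high number does not extend to every replacement of the 4-(trifluoromethyl)phenyl group, since the comparison with the first compound of the series reads a 1.4-fold lower number from compound 1 to compound 3 (0.14 log units; within the scatter) and places those two level. The position on a carbon with a double bond to nitrogen therefore accepts two different single six-membered aromatic rings, one of carbon only and one with a hetero atom, and the trifluoromethyl group is not needed to hold that level, while among these three compounds the high number is seen only with 3-methyl-1-phenyl-1H-pyrazol-4-yl. Nothing at hand gives a reason for either step.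

The pyrazolyl group differs from the other two in ring size, in its methyl and in its phenyl all at once, so these compounds cannot say which of those features goes with the high number. Also open, from the compounds shown here alone, is how this position would read with a plain pyrazol-4-yl, or with a six-membered aromatic ring carrying an amine or a carboxylic acid.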